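From 3,5-dichlorophenyl to 4-fluorophenyl on the amide nitrogen

A few compounds are considered here, and "the series" means these few. Any claim that something is new, unique, unknown or untested is made for them only; others in the source may bear on it.

Three compounds have been measured in a functional assay on HEK293 cells for agonist activity at D(4) dopamine receptor (Homo sapiens), read by FLIPR; on this read-out lower numbers stand for smaller maximal responses and higher numbers for larger maximal responses:
compound 1 `Cc1cc(C)cc(NC(=O)CN2CCC(c3cccc[n+]3[O-])CC2)c1` gives 76%
compound 2 `O=C(CN1CCC(c2cccc[n+]2[O-])CC1)Nc1ccc(F)cc1F` gives 74%
compound 3 `O=C(CN1CCC(c2cccc[n+]2[O-])CC1)Nc1cc(Cl)cc(Cl)c1` gives 68%

Compound 3 has the lowest of the three numbers, but the steps of a number 8 percentage points lower from compound 1 to compound 3 (within the scatter) and a number 6 percentage points lower from compound 2 to compound 3 (within the scatter) both lie within the scatter, as does a number 2 percentage points lower from compound 1 to compound 2 (within the scatter). Compound 4 `O=C(CN1CCC(c2cccc[n+]2[O-])CC1)Nc1ccc(F)cc1` differs from compound 3 only in the ring on the amide-type nitrogen: 4-fluorophenyl in place of 3,5-dichlorophenyl on an amide-type nitrogen. Every measured step also exchanged this ring, and none moved the response beyond the scatter. For compound 4 the expectation is therefore a number 4 percentage points higher from compound 3 to compound 4 (within the scatter) in this assay, that is, no change beyond the scatter. Compound 4 is estimated at 72%, with a range from 60% to 84%.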

Compound 4, largest response reached (reported as efficacy), in percent of the reference or control that the assay uses: 71%
The estimate for compound 4 lay 1 percentage points above the measured number, within the range that was stated.
By their numbers in this assay, from the lowest: compounds 3, 4, 2 and 1 (each within the scatter of the next).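

In this assay, a phenyl ring with a single fluoro group on the amide-type nitrogen gives the same picture as the rings with two substituents (a number 3 percentage points higher from compound 3 to compound 4 (within the scatter); a number 5 percentage points lower from compound 1 to compound 4 (within the scatter)). Even the smallest exchange so far, hydrogen in place of fluoro on an aromatic carbon, leaves the response within the scatter (a number 3 percentage points lower from compound 2 to compound 4 (within the scatter)). Nothing available explains why the response stays this flat.

All four rings carry only halogen or methyl groups. As far as these compounds go, whether the response also holds with a plain phenyl ring, or with a ring bearing an amine or a carboxylic acid, remains open.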